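A few compounds are considered here, and "the series" means these few. Any claim that something is new, unique, unknown or untested is made for them only; others in the source may bear on it.

Measured compounds:
Compound 1, `COc1ccc(NC(=O)/C(C#N)=C/c2cc(O)c(O)c([N+](=O)[O-])c2)cc1`, a functional assay on Bel-7402 cells (Homo sapiens) for antiproliferative activity, read by MTT assay; on this read-out higher numbers stand for weaker inhibition and lower numbers for stronger inhibition: > 100 ug/mL (a limit of the assay, not a number).
Compound 2, `N#C/C(=C\c1cc(O)c(O)c([N+](=O)[O-])c1)C(=O)Nc1ccccc1Cl`, this assay: 24 ug/mL.
Compound 3, `COc1cc(/C=C(\C#N)C(=O)Nc2cccc(Cl)c2)cc([N+](=O)[O-])c1O`, this assay: 21.1 ug/mL.

Compound 2 holds the higher of the two numbers in this assay, and compound 3 sits so close to it that the two values cannot be told apart; the value of compound 1 is only a limit, at which one of the three values sits (the limit of > 100 ug/mL in this assay, at which 1 of the 3 values shown sits). Among the measured compounds shown here, the one measured step, an at least 4.1-fold lower number from compound 1 to compound 2 (0.61 log units; beyond the scatter), shows that changing the group on the amide-type nitrogen can move the number far.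

Compound 4, `N#C/C(=C\c1cc(O)c(O)c([N+](=O)[O-])c1)C(=O)N1CCOCC1`, differs from compound 2 in a different way: morpholin-4-yl in place of (2-chlorophenyl)amino on a carbonyl carbon. No measured step replaces an arylamino group on the carbonyl carbon with a cyclic amine, so nothing shown covers this change directly, and the only measured step speaks just to how much an amide substituent can matter. The expectation for compound 4 therefore rests on compound 2 alone, with a wide margin in both directions. Compound 4 is expected to give a step of a 1.9-fold higher number from compound 2 to compound 4 (0.27 log units; within the scatter), leaning toward a higher number. Compound 4 is estimated at 45 ug/mL, between 12 ug/mL and 150 ug/mL.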

Compound 4, half-maximal inhibitory concentration: > 100 ug/mL
Compound 4: only a limit was reported (the forecaster's own chance of this, stated with the estimate: 30%); middle value at least 2.2-fold (0.34 log units) from the limit.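

Replacing (2-chlorophenyl)amino with morpholin-4-yl on the carbonyl carbon gives an at least 4.1-fold higher number from compound 2 to compound 4 (0.61 log units; beyond the scatter) in this assay, so this position does not tolerate every group: the earlier step covered only a swap of one substituted phenyl for another on the amide-type nitrogen, whereas this one removes the amide hydrogen and the aromatic ring together. Going by these compounds, for compound 4, > 100 ug/mL is a limit of the assay and not a number, so the true size of the step stays unknown. Compound 1 and compound 4 now stand at the same limit, and no order between them can be read: the limit of > 100 ug/mL in this assay, at which 2 of the 4 values shown sit.

The compounds shown do not separate the loss of the amide hydrogen, the loss of the aromatic ring and the arrival of the ring oxygen, since all three come with the one change. A cyclohexylamino group on the carbonyl carbon would keep the amide hydrogen without the aromatic ring, and a piperidin-1-yl group would keep the six-membered ring without the oxygen, so each would bear on a different part of the question.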